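The source may report more compounds than this note shows. Statements on the series, on what has been measured and on what is new or still open speak of the compounds shown alone.

Working notes on the series, with the read-out taken from a functional assay on PC-3 cells (Homo sapiens) for cytotoxicity, read by MTT assay, with a stated time of 72 h; on this read-out higher numbers stand for weaker inhibition and lower numbers for stronger inhibition:

compound 1, `C=C1C2=C(C(=O)N1OC)[C@H](O)[C@@](C)(O)[C@H](CCCCC)O2`: 32000 nM
compound 2, `C=C1C2=C(C(=O)N1OC)[C@H](OC(=O)CSc1nc3ccccc3s1)[C@@](C)(O)[C@H](CCCCC)O2`: 5000 nM
compound 3, `C=C1C2=C(C(=O)N1OC)[C@@H](F)[C@@](C)(O)[C@H](CCCCC)O2`: 12000 nM

Compound 2 holds the lowest number of the three in this assay. Its nearest neighbour is compound 3, whose number is higher by a gap beyond the scatter; compound 1 stands furthest from it, with the highest number of the set. No pair among these three differs in a single place, so no step is computed between them, and the three values are only read as they stand.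

The next compound is compound 4, `C=C1C2=C(C(=O)N1OC)[C@H](OC(=O)CSc1nc3ccccc3[nH]1)[C@@](C)(O)[C@H](CCCCC)O2`. It differs from compound 2 at one place:

1H-benzimidazol-2-yl in place of 1,3-benzothiazol-2-yl on a sulfur

The change keeps the ((1,3-benzothiazol-2-yl)sulfanyl)methyl branch in form and size and replaces it with the ((1H-benzimidazol-2-yl)sulfanyl)methyl branch. Within the data shown here, no measured pair shows the effect of such an exchange, so there is nothing to lean on beyond the value of compound 2 itself. The step of a 1.4-fold higher number from compound 2 to compound 4 (0.15 log units; within the scatter) is expected to be small, at most a modest rise in the number, and may well lie within the scatter. On that basis compound 4 is estimated at 7000 nM in this assay, with a range from 2500 nM to 20000 nM.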

Compound 4, half-maximal inhibitory concentration: 6400 nM
For compound 4 the middle estimate is 1.1-fold (0.04 log units) above the measured one; low and high end bracket the measured number.
By their numbers in this assay, from the lowest: compounds 2, 4 and 3 (each within the scatter of the next, the first and the last beyond it); then compound 1.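

In this assay, among these compounds, the exchange of 1,3-benzothiazol-2-yl for 1H-benzimidazol-2-yl on a sulfur gives a 1.3-fold higher number from compound 2 to compound 4 (0.11 log units; within the scatter) and is the first single-place step the series offers. At this place, on a sulfur whose other neighbour is a saturated chain carbon, one of these two groups can therefore stand for the other without a change that can be told from the scatter, even though the entering group has 1 hydrogen-bond donor and the leaving group has 0. Among the compounds shown here, this one step concerns only this pair of groups, and no supporting measurement is available to say why the two read alike.

Still open, on these data alone, is whether the read-out stays this flat when the group on the sulfur gives way to a plain phenyl, a pyridine or a short alkyl chain, or when the 1H-benzimidazol-2-yl group carries an amine or a carboxylic acid. Also open, as far as these compounds go, is whether the sulfur itself can be replaced by an oxygen or a methylene, and what a longer chain in the ((1H-benzimidazol-2-yl)sulfanyl)methyl branch would do.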